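The compounds below may be only part of what the source reports. "The series", "measured", "known", "first", "only" and "open" are said of these compounds alone.

Measured compounds in a functional assay on THP-1 cells (Homo sapiens) for cytotoxicity, read by MTT assay, with a stated time of 48 h; a higher number here means a weaker inhibitor, a lower number a stronger inhibitor:
- compound 1 `CCOc1ccc2nc(Nc3nc4ccc(F)cc4s3)sc2c1`, which gives 39000 nM
- compound 2 `CCOc1ccc2nc(Nc3nc4ccccc4s3)sc2c1`, which gives 37100 nM
- compound 3 `CCOc1ccc2nc(NC(=S)Nc3ccccc3)sc2c1`, which gives 43800 nM

The three measured compounds share the ethoxy-bearing core and sit close together in this assay. Compound 1 differs from compound 2 by fluoro in place of hydrogen on an aromatic carbon, and that change gave a 1.1-fold higher number from compound 2 to compound 1 (0.02 log units; within the scatter). Compound 3 carries a different partner on the core; the difference between the two cores of compound 3 and compound 2 is not broken down here, and their two values lie within the scatter of one another.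

Compound 4 `CCOc1ccc2nc(NC(=S)Nc3ccc(F)cc3)sc2c1` is not yet measured. It differs from compound 3 by fluoro in place of hydrogen on an aromatic carbon. The surroundings are not the same as in the earlier pair: there the fluoro entered a ring that is part of a fused or bridged system of two rings, meta to a fused ring and para to a fused ring, whereas here it enters a six-membered aromatic ring of carbon only, para to a large group. It is the same kind of change, not the same change. Going by the values given here, because the one measured instance gave a 1.1-fold higher number from compound 2 to compound 1 (0.02 log units; within the scatter), the step for compound 4 is expected to be a 1.0-fold higher number from compound 3 to compound 4 (0.01 log units; within the scatter), within the scatter. Compound 4 is therefore estimated at 45000 nM, between 25000 nM and 80000 nM.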

Compound 4, half-maximal inhibitory concentration: 39500 nM
Compound 4: the middle estimate sits 1.1-fold (0.06 log units) above what was measured; the measured number falls inside the stated range.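

Phenyl to 4-fluorophenyl gave a 1.1-fold lower number from compound 3 to compound 4 (0.04 log units; within the scatter) in this assay. Set beside the earlier instance of fluoro in place of hydrogen on an aromatic carbon, on the other core, the change reads alike on both: the same change on two cores in this assay, a 1.1-fold higher number (0.02 log units; within the scatter) from compound 2 to compound 1 and a 1.1-fold lower number (0.04 log units; within the scatter) from compound 3 to compound 4, 1.2-fold (0.07 log units) apart, within the scatter of two such steps. This shows that in these two pairs the change left the number within the scatter on either core, but it does not show that the two steps share a real effect, since steps this small cannot be told from no effect at all, nor does it show how fluoro would behave at another place or on a further core.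

The compounds shown leave open whether another group on that aromatic ring, such as chloro, methoxy or an amine, would move the number beyond the scatter. They also leave open whether replacing the ethoxy group with a longer chain or a hydroxyl would do so.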